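The source may hold more compounds than are shown below. What is called first, only, known or untested is meant among the compounds shown, and "the series" means these compounds.

Compound 1 `COc1ccc(-c2cc(/C=C/C(=O)c3ccc(N)cc3)[nH]n2)cc1` and compound 2 `COc1cc(-c2cc(/C=C/C(=O)c3ccc(N)cc3)[nH]n2)cc(OC)c1OC` share one core and differ only in the methoxy pattern on the aryl ring. In a functional assay on PC-3 cells (Homo sapiens) for inhibition, read by sulforhodamine B assay, with a stated time of 48 h (on this read-out lower numbers stand for higher toxicity in this test and higher numbers for lower toxicity in this test), compound 1 gives 39800 nM. In this assay compound 2 shows only a limit, > 100000 nM, and not a number. Of the two values at hand, one sits at this edge (the limit of > 100000 nM in this assay, at which 1 of the 2 values shown sits), so compound 2 stands at the top of what the assay reports. Compound 3 `COc1ccc(-c2cc(/C=C/C(=O)c3ccc(N)cc3)[nH]n2)cc1OC` is not yet measured in this assay. It differs from compound 2 by hydrogen in place of methoxy on an aromatic carbon. Going by the values given here, no step between two measured compounds exists for comparison. Compound 1, carrying a single methoxy group, does reach a number, 39800 nM, in this assay. Compound 3 is expected to step back from the limit, an at least 1.5-fold lower number from compound 2 to compound 3 (0.18 log units; that floor lies within the scatter), with a real chance of another limit. Compound 3 is estimated at 65000 nM, within 25000 nM to 150000 nM.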

Compound 3, concentration lethal to 50% of the cells: > 100000 nM
Compound 3: no number, only a limit (the forecaster's own chance of this, stated with the estimate: 40%); middle value at least 1.5-fold (0.18 log units) from the limit.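

In this assay compound 3 gives only a limit, > 100000 nM, so taking one methoxy off compound 2 does not bring a number back, and the step between these two limits cannot be read. Methoxy in place of hydrogen on an aromatic carbon gives an at least 2.5-fold higher number from compound 1 to compound 3 (0.40 log units; beyond the scatter), which shows that this one change on compound 1 is enough to reach the top of the read-out. The upper edge now holds most of the series: the limit of > 100000 nM in this assay, at which 2 of the 3 values shown sit.

On these data alone, how far compound 2 and compound 3 lie past that edge stays open, so any effect of the further methoxy on compound 2 remains unknown. As far as these compounds go, it is also open whether a smaller or different group at this position, such as fluorine or hydroxyl, would keep a measurable number as compound 1 does.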